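The source may hold more compounds than are shown below. What is called first, only, known or untested is meant among the compounds shown, and "the series" means these compounds.

compound 1 `O=C1C(Nc2ccccc2F)=CC(=O)c2c1nc1n2[C@H]2OC[C@@H](O)[C@H]2OC1`: 9820 nM
compound 2 `O=C1C=C(N2CCC2)C(=O)c2c1nc1n2[C@H]2OC[C@@H](O)[C@H]2OC1`: > 16000 nM

Among the compounds with values here, in a functional assay on HeLa cells (Homo sapiens) for inhibition, read by sulforhodamine B assay (on this read-out higher numbers stand for weaker inhibition and lower numbers for stronger inhibition), compound 1 gives 9820 nM, the only actual number in this small set. Compound 2 reads > 16000 nM, which is a limit of the assay and not a number. Within the data shown here, no step between measured compounds is available as a guide, so any expectation starts from compound 1 alone.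

Compound 3 `O=C1C(NC2CCCC2)=CC(=O)c2c1nc1n2[C@H]2OC[C@@H](O)[C@H]2OC1` keeps the shared core and carries cyclopentyl in place of 2-fluorophenyl on an amine nitrogen. In this assay, no change beyond the usual scatter is expected, and no direction is favoured. The expected step is a 1.0-fold higher number from compound 1 to compound 3 (0.01 log units; within the scatter), an estimate anchored on compound 1 at 9820 nM. For compound 3 the estimated value is 10000 nM, with an expected range from 4000 nM to 25000 nM.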

Compound 3, half-maximal inhibitory concentration: > 16000 nM
Compound 3: no number, only a limit (the forecaster's own chance of this, stated with the estimate: 20%); at least 1.6-fold (0.20 log units) between middle value and limit.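

On this amine nitrogen, cyclopentyl in place of 2-fluorophenyl gives an at least 1.6-fold higher number from compound 1 to compound 3 (0.21 log units; that floor lies within the scatter) in this assay, so the change brings no gain in inhibition that the read-out can show. The value for compound 3 is a limit and not a number, so the true size of the step cannot be read, and it may or may not exceed the scatter: the limit of > 16000 nM in this assay, at which 2 of the 3 values shown sit. Among the compounds shown, a reading below that limit thus appears only with the 2-fluorophenyl group of compound 1, which is a single example and not a pattern.

From the compounds shown here alone, what a plain phenyl or a benzyl on this amine nitrogen would read remains open. So does the question of whether the fluorine or the aromatic ring matters more for the measurable reading of compound 1.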